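This account rests on a few compounds, and the source may have more. Where it says the series, first, only, none or still open, it means among the compounds named here.

The measured compounds in a physicochemical assay for solubility, using the shake flask method, with a stated time of 48 h, at pH 6.5; a lower number here means a less soluble compound, a higher number a more soluble compound:
Compound 1 `Cn1cc(-c2cc(-c3cc(Cl)cc(OCC4CC4)c3)c(=O)n(-c3cccnc3)c2)c(=O)[nH]c1=O` gives 14.2 ug/mL.
Compound 2 `Cn1cc(-c2cc(-c3cc(Cl)cc(OCCC(F)(F)F)c3)c(=O)n(-c3cccnc3)c2)c(=O)[nH]c1=O` gives 57 ug/mL.
Compound 3 `Cn1cc(-c2cc(-c3cc(Cl)cc(OCc4ocnc4C(F)(F)F)c3)c(=O)n(-c3cccnc3)c2)c(=O)[nH]c1=O` gives 34.5 ug/mL.

Compound 3 stands second highest of the three numbers. Its nearest neighbour is compound 2, whose number lies within the scatter of it, and its furthest neighbour is reached by a 2.4-fold higher number from compound 1 to compound 3 (0.39 log units; beyond the scatter). The step of a 1.7-fold lower number from compound 2 to compound 3 (0.22 log units; within the scatter) shows that the group of 9 heavy atoms and the 2,2,2-trifluoroethyl give numbers that cannot be told apart here, whereas a 4.0-fold higher number from compound 1 to compound 2 (0.60 log units; beyond the scatter) is the larger change in this set.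

Compound 4 `Cn1cc(-c2cc(-c3cc(Cl)cc(OCc4scnc4C(F)(F)F)c3)c(=O)n(-c3cccnc3)c2)c(=O)[nH]c1=O` differs from compound 3 in one place: a group of 9 heavy atoms (4 carbon, 1 nitrogen, 3 fluorine, 1 sulfur; one five-membered aromatic ring with 2 hetero atoms) in place of a group of 9 heavy atoms (4 carbon, 1 nitrogen, 1 oxygen, 3 fluorine; one five-membered aromatic ring with 2 hetero atoms), on a saturated chain carbon bound to an oxygen on an aromatic ring. Among the compounds with values here, no measured step exchanges an oxygen for a sulfur inside the five-membered aromatic ring, so none bears directly on this change; the two steps from compound 1 replace the whole group on the saturated chain carbon, and the closest comparison available is a 1.7-fold lower number from compound 2 to compound 3 (0.22 log units; within the scatter), which stayed within the scatter. Compound 4 is therefore expected to land close to compound 3, with a 1.4-fold lower number from compound 3 to compound 4 (0.16 log units; within the scatter) expected to stay within the scatter. The estimate for compound 4 in this assay is 24 ug/mL, with a range from 10 ug/mL to 55 ug/mL.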

Compound 4, solubility: 24.8 ug/mL
Compound 4: middle estimate off by 1.0-fold (0.01 log units), on the low side; low and high end bracket the measured number.
By their numbers in this assay, from the lowest: compounds 1, 4, 3 and 2 (each within the scatter of the next, the first and the last beyond it).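

In this assay, exchanging the oxygen of the five-membered aromatic ring for sulfur, on a saturated chain carbon bound to an oxygen on an aromatic ring, gives two groups that cannot be told apart (a 1.4-fold lower number from compound 3 to compound 4 (0.14 log units; within the scatter)). The sulfur-containing group does separate from 2,2,2-trifluoroethyl (a 2.3-fold lower number from compound 2 to compound 4 (0.36 log units; beyond the scatter)), yet it cannot be told apart from cyclopropyl (a 1.7-fold higher number from compound 1 to compound 4 (0.24 log units; within the scatter)), whereas the oxygen-containing group stood beyond the scatter of cyclopropyl (a 2.4-fold higher number from compound 1 to compound 3 (0.39 log units; beyond the scatter)); since compound 3 and compound 4 lie within the scatter of each other, this contrast is slight. Nothing measured here explains these steps.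

The compounds shown leave open how the five-membered aromatic ring would read with a nitrile or a methyl in place of its trifluoromethyl. They also leave open whether an amine or a carboxylic acid at this place would fall outside the span of these four compounds.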